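Hydroxy to methoxy: from compound 3 to compound 4

The source may report more compounds than this note shows. Statements on the series, on what has been measured and on what is new or still open speak of the compounds shown alone.

Three compounds share one core and differ in a single group. In a functional assay on Gurav cells (Homo sapiens) for inhibition, read by sulforhodamine B assay (a higher number here means a weaker inhibitor of growth, a lower number a stronger inhibitor of growth), compound 1 `Fc1ccc(-c2ccc(-c3ccc(-c4nc5ccccc5[nH]4)cc3)cc2)cc1`, which carries fluoro, gives 100000 nM. Compound 2 `FC(F)(F)c1ccc(-c2ccc(-c3ccc(-c4nc5ccccc5[nH]4)cc3)cc2)cc1`, which carries trifluoromethyl, gives 39100 nM. Compound 3 `Oc1ccc(-c2ccc(-c3ccc(-c4nc5ccccc5[nH]4)cc3)cc2)cc1`, which carries hydroxy, gives 100000 nM. That puts compound 3 level with compound 1, and the two share the highest number of the three.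

Compound 4 `COc1ccc(-c2ccc(-c3ccc(-c4nc5ccccc5[nH]4)cc3)cc2)cc1` has methyl in place of hydrogen on an oxygen on an aromatic ring, so its hydroxy becomes methoxy. Among the compounds with values here, no measured step makes this exact change, and methoxy has not yet been tested. The nearest evidence comes from swaps of the group at this same place. The swap of fluoro for hydroxy shows no change at the digits printed from compound 1 to compound 3 (within the scatter). The swaps involving trifluoromethyl are modest, with a 2.6-fold lower number from compound 1 to compound 2 (0.41 log units; beyond the scatter) and a 2.6-fold higher number from compound 2 to compound 3 (0.41 log units; beyond the scatter). Changes here have therefore moved this assay only a little, or not at all, so a large step would be a surprise. The expected result is a 1.4-fold lower number from compound 3 to compound 4 (0.15 log units; within the scatter), a slight lean toward a lower number that stays within the scatter. For compound 4 the estimated value is 70000 nM, with an expected range of 30000 nM to 100000 nM.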

Compound 4, concentration for 50% growth inhibition: 38100 nM
The estimate for compound 4 lay 1.8-fold (0.26 log units) above the measured number; the range from low to high includes it.
By their numbers in this assay, from the lowest: compounds 4 and 2 (each within the scatter of the next); then compounds 1 and 3 (each within the scatter of the next).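

Putting a methyl on the oxygen does what swapping fluoro for hydroxy did not do at this position: in this assay there is a 2.6-fold lower number from compound 3 to compound 4 (0.42 log units; beyond the scatter) and so a small but real gain in growth inhibition, even though only the hydrogen on that oxygen has changed. Methoxy also ends up level with trifluoromethyl, with a 1.0-fold lower number from compound 2 to compound 4 (0.01 log units; within the scatter) and a 2.6-fold lower number from compound 1 to compound 4 (0.42 log units; beyond the scatter) as well, so among these four compounds the two groups compounds 2 and 4 carry sit together at the lower numbers, while the fluoro of compound 1 and the hydroxy of compound 3 sit together at the higher ones. Nothing available here bears on why methoxy and trifluoromethyl, two quite different groups, should land at the same level.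

Still open, from the compounds shown here alone, is whether a longer chain on the same oxygen, such as ethoxy, would take the number lower than in compound 4 or would leave it unchanged. It is equally unknown how an amine or a carboxylic acid at this place on the ring would compare with methoxy and with hydroxy.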